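Stereochemical definition at the chain carbon of compound 1

The compounds below may be only part of what the source reports. "The series", "measured", "known", "first", "only" and "open" are said of these compounds alone.

Measured compounds:
- compound 1, `C[C@@H](Sc1nc2c(cnn2C)c(=O)n1-c1ccccc1)c1ccccc1`: 40 nM
- compound 2, `CC(Sc1nc2nn(C3COC3)cc2c(=O)n1-c1ccccc1)c1cccnc1`: 58 nM
- compound 3, `CC(Sc1nc2nn(C3COC3)cc2c(=O)n1-c1ccccc1)c1ccccc1`: 65 nM

For the measured compounds named here, in an assay on isolated protein for inhibition of retinal dehydrogenase 2 (Homo sapiens) (on this read-out lower numbers stand for stronger inhibition and higher numbers for weaker inhibition), compound 1 gives 40 nM, the lowest of the three numbers; compound 2 and compound 3, both drawn without a configuration at the chain carbon, lie within the scatter of it, and the one measured step, a 1.1-fold higher number from compound 2 to compound 3 (0.05 log units; within the scatter), is also within the scatter.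

Compound 4, `CC(Sc1nc2c(cnn2C)c(=O)n1-c1ccccc1)c1ccccc1`, is the next compound. The difference: the two compounds have the same atoms and bonds; at least one stereo element is drawn with a configuration in one of them and without one in the other: 1 of 1 stereo elements differ; a stereocentre at a saturated chain carbon is drawn R in compound 1 and without a configuration in compound 4. No measured step bears on drawing the stereocentre with or without a configuration; the only step shown concerns the aromatic group on the chain carbon, not the stereocentre. Compound 2 and compound 3, undefined at that centre, sit close to compound 1, which gives no sign of a large effect. A step that is small, toward a higher number, is expected for compound 4 in this assay: a 1.8-fold higher number from compound 1 to compound 4 (0.24 log units; within the scatter). The estimate for compound 4 is 70 nM, with a range from 35 nM to 160 nM.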

Compound 4, half-maximal inhibitory concentration: 110 nM
Compound 4: middle estimate off by 1.6-fold (0.20 log units), on the low side, within the range that was stated.
By their numbers in this assay, from the lowest: compounds 1, 2, 3 and 4 (each within the scatter of the next, the first and the last beyond it).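

In this assay, for the compounds shown here, the stereocentre at the saturated chain carbon now has a measured step of its own, a 2.8-fold higher number from compound 1 to compound 4 (0.44 log units; beyond the scatter), whereas the one earlier step concerned only the aromatic group on that carbon. With atoms and bonds identical in the pair, the step goes with a single difference: the fact that one of compounds 1 and 4 is drawn with a defined configuration and the other without, at the place where they differ

Whether a configuration is drawn at this carbon therefore counts in this series, which compound 2 and compound 3, both undefined there, could not show.

Open, on these data alone, is the number for the same structure drawn S at this carbon, and whether compound 2 and compound 3 would shift in the same way if drawn R. Also open is how the configuration would count with a longer chain on the chain carbon in place of the present saturated one.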